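Swapping the isopropyl carbamate for an oxolane ester

A few compounds are considered here, and "the series" means these few. Any claim that something is new, unique, unknown or untested is made for them only; others in the source may bear on it.

Compound 1 `CC(C)OC(=O)N1CCC(O[C@H]2CC[C@H](Oc3ccc(S(C)(=O)=O)nc3)CC2)CC1` gives 201 nM in a functional assay on isolated protein for agonist activity at Glucose-dependent insulinotropic receptor (Rattus norvegicus), read by HTRF and cAMP accumulation; a lower number here means that less compound is needed, a higher number that more compound is needed for the effect.
Compound 2 `CC(C)OC(=O)N1CCC(O[C@H]2CC[C@H](Oc3cnc(S(C)(=O)=O)cn3)CC2)CC1` gives 119 nM in this assay.

Compound 2 and compound 1 cannot be told apart, since the step of a 1.7-fold lower number from compound 1 to compound 2 (0.23 log units; within the scatter) lies within the scatter. Compound 3 `CS(=O)(=O)c1cnc(O[C@H]2CC[C@H](OC3CCN(C(=O)OC4CCOC4)CC3)CC2)cn1` differs from compound 2 by oxolan-3-yl in place of isopropyl on an oxygen next to a carbonyl group. For the measured compounds named here, the one measured step concerns a different part of the molecule, so nothing measured bears on this change, and no step beyond the scatter is expected in this assay. Compound 3 is therefore estimated at 130 nM, with a range from 50 nM to 350 nM. That estimate means a step of a 1.1-fold higher number from compound 2 to compound 3 (0.04 log units; within the scatter).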

Compound 3, half-maximal effective concentration: 1500 nM
Compound 3: middle estimate off by 12-fold (1.06 log units), on the low side, and the stated range ends below it.
By their numbers in this assay, from the lowest: compounds 2 and 1 (each within the scatter of the next); then compound 3.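

This position on the carbamate oxygen is sensitive in this assay, unlike the change in the sulfonyl-bearing ring: oxolan-3-yl in place of isopropyl gives a 13-fold higher number from compound 2 to compound 3 (1.10 log units; beyond the scatter). The entering group brings a five-membered ring and a hydrogen-bond acceptor together, so this single step cannot separate their contributions. Nothing measured here explains why the number rises.

Cyclopentyl, which keeps a five-membered ring but has no ring oxygen, would help to separate the two. Going by these compounds, whether it stays close to compound 2 remains open.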